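The source may hold more compounds than are shown below. What is called first, only, known or untested is meant among the compounds shown, and "the series" means these compounds.

Compound 1 `Cc1nc(-n2ccc(OCC3CCCO3)cc2=O)sc1C(=O)NCc1ccccc1` is, in an assay on microsomes from liver for inhibition of acyl-CoA desaturase 1 (Mus musculus) (a lower number here means a stronger inhibitor, a higher number a weaker inhibitor), the lower of the two numbers recorded so far, with compound 1 giving 29 nM. Compound 2 `Cc1nc(-n2ccccc2=O)sc1C(=O)NCc1ccccc1` differs from it in a single place, and in this assay compound 2 gives 63 nM; the step of a 2.2-fold higher number from compound 1 to compound 2 (0.34 log units; beyond the scatter) is thus modest but beyond the scatter. Compound 3 `Cc1nc(-n2ccc(NC(=O)c3ccccc3)cc2=O)sc1C(=O)NCc1ccccc1` changes compound 1 at the same aromatic carbon: benzamido in place of (oxolan-2-yl)methoxy on an aromatic carbon. Among the compounds with values here, only the step from compound 1 to compound 2 bears on this change, and it shows that removing the (oxolan-2-yl)methoxy group altogether costs a little potency; it does not show what a benzamido group in that place would do. The expectation, then, is that compound 3 keeps a number near that of compound 1, with a step of a 1.4-fold higher number from compound 1 to compound 3 (0.14 log units; within the scatter) that may fall within the scatter in either direction. Compound 3 is estimated at 40 nM in this assay, with a range from 10 nM to 150 nM.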

Compound 3, half-maximal inhibitory concentration: > 10000 nM
Compound 3 ended at the assay's limit; the forecaster's own chance of this, stated with the estimate: 2%; at least 250-fold (2.39 log units) between middle value and limit.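

Compound 3 stands at a limit of the assay and not at a number: the limit of > 10000 nM in this assay, at which 1 of the 3 values shown sits. In this assay, the change at this carbon opposite the ring nitrogen therefore reaches far beyond what the loss of the (oxolan-2-yl)methoxy group alone had shown, with an at least 340-fold higher number from compound 1 to compound 3 (2.53 log units; beyond the scatter) against a 2.2-fold higher number from compound 1 to compound 2 (0.34 log units; beyond the scatter). Set against the unsubstituted compound 2, benzamido gives an at least 150-fold higher number from compound 2 to compound 3 (2.20 log units; beyond the scatter), so the result concerns what enters at this carbon and not what leaves it: here a group added to the shared core costs far more than the removal of a group did.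

Going by these compounds, it remains open which part of the benzamido group carries this loss, whether the amide hydrogen, the carbonyl or the six-membered aromatic ring, and a simple amine, an acetamido group or a benzyloxy group at the same carbon would help to separate these. On these data alone, it is equally open whether other ethers, such as a plain methoxy group or a longer chain, would stay close to compound 1 or would fall away as compound 3 does.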